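This account rests on a few compounds, and the source may have more. Where it says the series, first, only, none or still open, it means among the compounds named here.

Compound 1 `CCOC(=O)C12C(=O)OCC=C1COC2c1ccccc1F`: > 1000000 nM
Compound 2 `CCOC(=O)C12C(=O)OCC=C1COC2c1cc(OC)c(OC)c(OC)c1`: > 1000000 nM

In a functional assay on QGY cells (Homo sapiens) for cytotoxicity, read by MTT assay (a higher number here means a weaker inhibitor, a lower number a stronger inhibitor), compound 1 gives only a limit, > 1000000 nM, not a number. Compound 2 likewise sits at a limit, > 1000000 nM. Both measured values therefore rest at the limit of > 1000000 nM in this assay, at which 2 of the 2 values shown sit, and compound 1 stands there with no number to rank it. Compound 3 `CCOC(=O)C12C(=O)OCC=C1COC2c1cccs1` differs from compound 1 by thiophen-2-yl in place of 2-fluorophenyl on a saturated ring carbon. Among the compounds with values here, with no step between measured compounds known, the expected step of a number no higher from compound 1 to compound 3 (the limit leaves the size open) is none beyond the scatter. Compound 3 is accordingly estimated at 1000000 nM, in a range from 300000 nM to 3000000 nM, most likely again reported only as a limit.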

Compound 3, half-maximal inhibitory concentration: > 1000000 nM
Compound 3: a limit, no number; the forecaster's own chance of this, stated with the estimate: 85%; the middle value lies on the limit itself.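

Compound 1 and compound 3 both give only limits in this assay, so no step between them can be read: the limit of > 1000000 nM in this assay, at which 3 of the 3 values shown sit.

The compounds shown leave open whether any group in this place would give an actual number rather than a limit.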